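This account rests on a few compounds, and the source may have more. Where it says the series, first, only, none or still open, it means among the compounds named here.

Measured compounds in an assay on isolated protein for inhibition of protein deacetylase HDAC6 (Homo sapiens), read by fluorescence, with a stated time of 1 h, tested at 100 nM; a lower number here means less inhibition, a higher number more inhibition at the concentration tested (going by the name of the read-out):
compound 1 `O=C(/C=C/c1ccc(OCc2nc(C3CCN(Cc4ccccc4F)CC3)no2)cc1)NO` gives 68%
compound 2 `O=C(/C=C/c1ccc(OCc2nc(C3CCN(Cc4cccc(F)c4)CC3)no2)cc1)NO` gives 73%
compound 3 `O=C(/C=C/c1ccc(OCc2nc(C3CCN(Cc4ccc(Br)cc4)CC3)no2)cc1)NO` gives 58%

Compound 1 stands second of the three numbers, within the scatter of both neighbours: a number 5 percentage points higher from compound 1 to compound 2 (within the scatter) and a number 10 percentage points lower from compound 1 to compound 3 (within the scatter). Only a number 15 percentage points lower from compound 2 to compound 3 (beyond the scatter) lies beyond the scatter. Compound 4 `O=C(/C=C/c1ccc(OCc2nc(C3CCN(Cc4ccccc4[N+](=O)[O-])CC3)no2)cc1)NO` differs from compound 1 by nitro in place of fluoro on an aromatic carbon. No measured step exchanges fluoro for nitro; the three steps shown move or exchange a halogen on the same aromatic ring and stay small, so nothing here supports a step beyond the scatter in this assay. For compound 4 the expected step is therefore a number 3 percentage points lower from compound 1 to compound 4 (within the scatter). Compound 4 is accordingly estimated at 65%, in the range 50% to 78%.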

Compound 4, a percentage reported as inhibition, at one concentration (the size of the read-out at that concentration, not a potency): 63%
Compound 4: the middle estimate sits 2 percentage points above what was measured, and the stated range covers the measured number.
By their numbers in this assay, from the lowest: compounds 3, 4, 1 and 2 (each within the scatter of the next, the first and the last beyond it).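

In this assay, among the compounds shown here, the earlier compounds varied only a halogen on this ring, whereas nitro, with its 3 heavy atoms and 2 hydrogen-bond acceptors, replaces fluoro here with a number 5 percentage points lower from compound 1 to compound 4 (within the scatter) and so stays within the scatter. Compound 4 also shows a number 5 percentage points higher from compound 3 to compound 4 (within the scatter) and a number 10 percentage points lower from compound 2 to compound 4 (within the scatter) and thus lies within the scatter of all three earlier compounds. No evidence at hand bears on why this step stays small.

Still open, going by these compounds, is whether an amine or a carboxylic acid on this aromatic carbon would also stay within the scatter.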